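The source may report more compounds than this note shows. Statements on the series, on what has been measured and on what is new or still open speak of the compounds shown alone.

Working notes on the series. Compound 3 `CN(C)Cc1ccc2nc(NC(=O)N/N=C/c3c[nH]c4ccccc34)sc2c1` carries hydrogen on the aromatic nitrogen of the shared core; in a functional assay on MDA-MB-231 cells (Homo sapiens) for cytotoxicity, read by MTT assay, with a stated time of 72 h (on this read-out lower numbers stand for stronger inhibition and higher numbers for weaker inhibition), compound 3 gives 1190 nM. Compound 1 `CN(C)Cc1ccc2nc(NC(=O)N/N=C/c3cn(Cc4ccccc4Cl)c4ccccc34)sc2c1` gives 1180 nM and compound 2 `CN(C)Cc1ccc2nc(NC(=O)N/N=C/c3cn(Cc4ccc(Cl)cc4Cl)c4ccccc34)sc2c1` gives 1410 nM, so compound 3 sits within the scatter of both, as shown by a 1.0-fold higher number from compound 1 to compound 3 (0.00 log units; within the scatter) and a 1.2-fold lower number from compound 2 to compound 3 (0.07 log units; within the scatter). Compound 4 `CN(C)Cc1ccc2nc(NC(=O)N/N=C/c3cn(Cc4ccc(Cl)cc4)c4ccccc34)sc2c1` is the next step from compound 3: 4-chlorobenzyl in place of hydrogen on an aromatic nitrogen. The two measured steps that removed a substituted benzyl from this nitrogen both stayed within the scatter, so restoring a 4-chlorobenzyl is expected to give no step beyond the scatter in this assay. For compound 4 the step is expected to be a 1.0-fold higher number from compound 3 to compound 4 (0.00 log units; within the scatter). Compound 4 is therefore estimated at 1200 nM, in the range 600 nM to 2400 nM.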

Compound 4, half-maximal inhibitory concentration: 880 nM
Estimate against measurement, compound 4: 1.4-fold (0.13 log units) above, within the range that was stated.
By their numbers in this assay, from the lowest: compounds 4, 1, 3 and 2 (each within the scatter of the next).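

In this assay, a third substituted benzyl on the aromatic nitrogen also stays within the scatter of the compound with hydrogen there (a 1.4-fold lower number from compound 3 to compound 4 (0.13 log units; within the scatter)). Neither hydrogen in place of chloro on the 2,4-dichlorobenzyl (a 1.6-fold lower number from compound 2 to compound 4 (0.20 log units; within the scatter)) nor 4-chlorobenzyl in place of 2-chlorobenzyl (a 1.3-fold lower number from compound 1 to compound 4 (0.13 log units; within the scatter)) gives a step beyond the scatter, so neither the count nor the place of chloro separates these four compounds. Nothing available accounts for these small steps. The compounds shown leave open whether an amine or a carboxylic acid on this benzyl, or a longer chain on this nitrogen, would give a step beyond the scatter.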